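The source may hold more compounds than are shown below. What is called first, only, known or untested is meant among the compounds shown, and "the series" means these compounds.

Three compounds have been measured in a functional assay on a cell-free system (Platelet, plasma, Homo sapiens) for inhibition; a lower number here means a stronger inhibitor, a higher number a weaker inhibitor:

compound 1 `O=C(O)CN1Cc2ccc(NC(=O)CCCC3CCNCC3)cc2C1=O`, 66000 nM
compound 2 `O=C(O)CCN1Cc2ccc(NC(=O)CCCC3CCNCC3)cc2C1=O`, 5900 nM
compound 3 `CC(CC(=O)O)N1Cc2ccc(NC(=O)CCCC3CCNCC3)cc2C1=O`, 5400 nM

Compound 3 gives the lowest number of the three, yet the step of a 1.1-fold lower number from compound 2 to compound 3 (0.04 log units; within the scatter) is within the scatter, so compound 2 and compound 3 cannot be ranked against each other; only compound 1 stands clearly apart, by a 12-fold lower number from compound 1 to compound 3 (1.09 log units; beyond the scatter). The unmeasured compound 4 `O=C(O)CCCN1Cc2ccc(NC(=O)CCCC3CCNCC3)cc2C1=O` differs from compound 3 in one place: 3-carboxypropyl in place of 1-(carboxymethyl)ethyl on an amide-type nitrogen in a ring. Both compounds carry a chain ending in a carboxylic acid on the same ring nitrogen, and the chains contain the same atoms joined differently. The measured steps that speak to this are an 11-fold lower number from compound 1 to compound 2 (1.05 log units; beyond the scatter), a large gain when carboxymethyl replaced carboxy, and a 1.1-fold lower number from compound 2 to compound 3 (0.04 log units; within the scatter), which shows that methyl in place of hydrogen on that chain made no difference beyond the scatter. Neither step tests the 3-carboxypropyl chain itself, so the direction is uncertain and only a modest change is expected. Compound 4 is estimated at 3500 nM, with a range from 700 nM to 17000 nM. That estimate corresponds to an expected step of a 1.5-fold lower number from compound 3 to compound 4 (0.19 log units; within the scatter), which may well fall within the scatter.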

Compound 4, half-maximal inhibitory concentration: 51000 nM
Beside the measured number, compound 4's estimate is 15-fold (1.16 log units) below it; the whole stated range lies below it.
By their numbers in this assay, from the lowest: compounds 3 and 2 (each within the scatter of the next); then compounds 4 and 1 (each within the scatter of the next).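

In this assay, this position on the amide-type nitrogen proves sensitive to how the chain is built, not only to what it contains: moving from 1-(carboxymethyl)ethyl to 3-carboxypropyl, with the same atoms joined differently, gives a 9.4-fold higher number from compound 3 to compound 4 (0.98 log units; beyond the scatter). Extending the chain of compound 2 by one carbon gives an 8.6-fold higher number from compound 2 to compound 4 (0.94 log units; beyond the scatter), so the large gain seen on going from carboxymethyl to 2-carboxyethyl does not continue as the chain grows. The shorter carboxymethyl chain and the longer 3-carboxypropyl chain cannot be told apart, with a 1.3-fold lower number from compound 1 to compound 4 (0.11 log units; within the scatter), so among these unbranched chains the best number belongs to the intermediate 2-carboxyethyl chain of compound 2, and both one carbon less and one carbon more cost activity.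

No measurement here explains why the way the chain is joined matters so much. The compounds shown leave open how a still longer chain such as 4-carboxybutyl would behave, and whether an ester or an amide could stand in for the carboxylic acid at the chain end.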